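Hydroxy in place of oxolanyl ether: cytotoxicity note

The source may hold more compounds than are shown below. What is called first, only, known or untested is meant among the compounds shown, and "the series" means these compounds.

Compound 1 `CC(C)(C)C#Cc1cc(N(C(=O)[C@H]2CC[C@H](C)CC2)[C@H]2CC[C@H](OC3CCOC3)CC2)c(C(=O)O)s1` stands only at a limit in an ADME assay on MT4 cells (Homo sapiens) for cytotoxicity, with a stated time of 5 days; on this read-out lower numbers stand for higher toxicity in this test and higher numbers for lower toxicity in this test: compound 1 gives > 20000 nM, a limit of the assay, not a number. Compound 2 `CC(C)N(c1cc(C#CC(C)(C)C)sc1C(=O)O)C(=O)[C@H]1CC[C@H](Cl)CC1` also gives > 20000 nM, again a limit. Within the data shown here, both values thus sit at the limit of > 20000 nM in this assay, at which 2 of the 2 values shown sit, so no measured step between compounds can be drawn. Compound 3 `CC(C)(C)C#Cc1cc(N(C(=O)[C@H]2CC[C@H](C)CC2)[C@H]2CC[C@H](O)CC2)c(C(=O)O)s1` differs from compound 1 by hydrogen in place of oxolan-3-yl on an oxygen on a saturated carbon. Among the measured compounds shown here, with no step to guide, no change beyond the scatter is expected for a step that the limit leaves unreadable from compound 1 to compound 3, and compound 3 is expected to remain at the limit. Compound 3 is estimated at 30000 nM, within 15000 nM to 100000 nM.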

Compound 3, half-maximal cytotoxic concentration: > 20000 nM
Compound 3 ended at the assay's limit; the forecaster's own chance of this, stated with the estimate: 85%; the middle value is on the limit's open side.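

No step can be read from compound 1 to compound 3, because both stand only at a limit: the limit of > 20000 nM in this assay, at which 3 of the 3 values shown sit.

The compounds shown leave open the size of any cytotoxicity change from (oxolan-3-yl)oxy to hydroxy.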